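Oxindole-benzimidazole series: chloro for methyl at the oxindole ring

A few compounds are considered here, and "the series" means these few. Any claim that something is new, unique, unknown or untested is made for them only; others in the source may bear on it.

Measured compounds:
compound 1 `CC(C)n1c(/C=C2/C(=O)Nc3ccc(F)cc32)nc2ccccc21` — 20800 nM
compound 2 `CCn1c(/C=C2/C(=O)Nc3ccc(C)cc32)nc2ccccc21` — 38600 nM
compound 3 `Cn1c(/C=C2/C(=O)Nc3ccc(F)cc32)nc2ccccc21` — 34300 nM

All three were tested in a functional assay on PC-3 cells (Homo sapiens) for cytotoxicity, read by MTT assay, with a stated time of 48 h; a higher number here means a weaker inhibitor, a lower number a stronger inhibitor. Compound 2 gives the highest of the three numbers in this assay, but its gap to compound 3 and its gap to compound 1 both lie within the usual scatter, so the three cannot be told apart. Going by the values given here, the one measured step, a 1.6-fold higher number from compound 1 to compound 3 (0.22 log units; within the scatter), concerns the substituent on the aromatic nitrogen and is itself within the scatter.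

Compound 4 `CCn1c(/C=C2/C(=O)Nc3ccc(Cl)cc32)nc2ccccc21` is not yet measured. It differs from compound 2 by chloro in place of methyl on an aromatic carbon. Among the compounds with values here, no measured step touches this position: compound 1 and compound 3 carry fluoro there and compound 2 carries methyl, and their numbers are all within the scatter of one another. Nothing in the series therefore points to a change beyond the scatter, and the step from compound 2 to compound 4 is expected to be a 1.3-fold lower number from compound 2 to compound 4 (0.11 log units; within the scatter), in no particular direction. Compound 4 is estimated at 30000 nM, with a range from 12000 nM to 80000 nM.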

Compound 4, half-maximal inhibitory concentration: > 50000 nM
Compound 4: only a limit was reported (the forecaster's own chance of this, stated with the estimate: 5%); middle value at least 1.6-fold (0.22 log units) from the limit.
By their numbers in this assay, from the lowest: compounds 1, 3 and 2 (each within the scatter of the next). At a limit, above all of these: compound 4.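

In this assay compound 4 gives > 50000 nM as a limit and not a number. Chloro in place of methyl on this aromatic carbon now has a step of its own, an at least 1.2-fold higher number from compound 2 to compound 4 (0.11 log units; that floor lies within the scatter) as the only reading, and that floor does not separate the pair. From the compounds shown here alone, the full size of the step stays unknown because only a limit is available, which leaves room for a larger change at this position: the limit of > 50000 nM in this assay, at which 1 of the 4 values shown sits.

Still open, going by these compounds, is whether fluoro, carried by compound 1 and compound 3, would read differently from chloro and methyl at this position with the ethyl group kept on the aromatic nitrogen. Also open, on these data alone, is whether an amine or a methoxy group here would give a number that can be told apart from compound 2.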